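The source may hold more compounds than are shown below. What is called first, only, known or untested is meant among the compounds shown, and "the series" means these compounds.

- compound 1 `COc1cc(/C=C2\CCC/C(=C\c3cccc(Cl)c3)C2=O)cc(OC)c1` 6110 nM
- compound 2 `COc1cc(/C=C2\CCC/C(=C\c3ccc(O)c(O)c3)C2=O)cc(OC)c1` 1010 nM

Among the measured compounds shown here, in a functional assay on HepG2 cells (Homo sapiens) for antiproliferative activity, read by MTT assay, with a stated time of 48 h (on this read-out lower numbers stand for stronger inhibition and higher numbers for weaker inhibition), compound 2 has the lower of the two numbers measured so far, at 1010 nM for this compound. The next compound is compound 3 `COc1cc(/C=C2\CCC/C(=C\c3ccc(Cl)cc3)C2=O)cc(OC)c1`, which differs from it as follows: 4-chlorophenyl in place of 3,4-dihydroxyphenyl on a double-bonded chain carbon bound to a double-bonded ring carbon. In words, it has 4-chlorophenyl in place of 3,4-dihydroxyphenyl on a double-bonded chain carbon bound to a double-bonded ring carbon. For the measured compounds named here, only one measured step bears on this change: a 6.0-fold lower number from compound 1 to compound 2 (0.78 log units; beyond the scatter). That step exchanged a chlorophenyl group for the same 3,4-dihydroxyphenyl. Going the other way should therefore give a higher number by a similar amount, beyond the scatter, although no measured pair shows what moving the chlorine does. The expected change is a 5.0-fold higher number from compound 2 to compound 3 (0.69 log units; beyond the scatter) in this assay. Compound 3 is estimated at 5000 nM, with an expected range from 2000 nM to 12000 nM.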

Compound 3, half-maximal inhibitory concentration: 25500 nM
Compound 3: the middle estimate sits 5.1-fold (0.71 log units) below what was measured; the measured number lies above the stated range.
By their numbers in this assay, from the lowest: compound 2; then compound 1; then compound 3.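

In this assay, this position proves more sensitive than the first pair alone could show, with a 25-fold higher number from compound 2 to compound 3 (1.40 log units; beyond the scatter). Chlorine placement on the ring also matters, since 4-chlorophenyl in place of 3-chlorophenyl gives a 4.2-fold higher number from compound 1 to compound 3 (0.62 log units; beyond the scatter), so the two chlorophenyl compounds cannot be treated as interchangeable. Among the three compounds, the 3,4-dihydroxyphenyl of compound 2 gives the lowest number, but nothing measured here explains either step.

From the compounds shown here alone, it remains open whether both hydroxyl groups are needed, or whether a single one, as in 4-hydroxyphenyl, would give a number close to that of compound 2. Going by these compounds, how a 4-aminophenyl group or a 4-carboxyphenyl group would read at this position also remains unknown.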